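A few compounds are considered here, and "the series" means these few. Any claim that something is new, unique, unknown or untested is made for them only; others in the source may bear on it.

In a physicochemical assay for solubility, in phosphate buffer, with a stated time of 24 h, at pH 7.4, tested at 100 uM (on this read-out lower numbers stand for lower solubility and higher numbers for higher solubility), compound 1 `CCCn1cc(S(=O)(=O)c2ccc(CNC(=O)N3Cc4ccncc4C3)cc2)cn1` reads 105000 nM while compound 2 `O=C(NCc1ccc(S(=O)(=O)C2CCOCC2)cc1)N1Cc2ccncc2C1` reads 206000 nM and compound 3 `CCC(=O)N1CCC(S(=O)(=O)c2ccc(CNC(=O)N3Cc4ccncc4C3)cc2)CC1` reads 216000 nM on the same scale. Compound 3 shares the upper end of these numbers with compound 2. Among the compounds with values here, compound 4 `CN1CCC(S(=O)(=O)c2ccc(CNC(=O)N3Cc4ccncc4C3)cc2)CC1` carries methyl in place of propanoyl on an amine nitrogen in a ring and no measured step makes this exact change. The nearest evidence is compound 3 against its two neighbours, whole-group swaps on a sulfonyl sulfur, with a 1.0-fold higher number from compound 2 to compound 3 (0.02 log units; within the scatter) and a 2.1-fold higher number from compound 1 to compound 3 (0.31 log units; beyond the scatter) as the measure. No step beyond the scatter is therefore expected in this assay for this swap. The estimated step is a 1.1-fold lower number from compound 3 to compound 4 (0.03 log units; within the scatter) in size. For compound 4 the expected value is 200000 nM with an estimated range of 110000 nM to 350000 nM as the likely span.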

Compound 4, solubility: 240000 nM
Beside the measured number, compound 4's estimate is 1.2-fold (0.08 log units) below it, and the stated range covers the measured number.
By their numbers in this assay, from the lowest: compounds 1, 2, 3 and 4 (each within the scatter of the next, the first and the last beyond it).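

In this assay, replacing propanoyl with methyl on the ring amine nitrogen gives a 1.1-fold higher number from compound 3 to compound 4 (0.05 log units; within the scatter), so the read-out does not separate these two groups at this position. Compound 4 likewise cannot be separated from the oxan-4-yl compound, with a 1.2-fold higher number from compound 2 to compound 4 (0.07 log units; within the scatter), while a 2.3-fold higher number from compound 1 to compound 4 (0.36 log units; beyond the scatter) shows that the 1-methylpiperidin-4-yl group, like the 1-propanoylpiperidin-4-yl group, stands clear of the 1-propyl-1H-pyrazol-4-yl group. Nothing measured here explains these numbers. As far as these compounds go, it remains open how this nitrogen would read with a hydrogen, a longer chain or a carboxylic acid on it.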